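A few compounds are considered here, and "the series" means these few. Any claim that something is new, unique, unknown or untested is made for them only; others in the source may bear on it.

Measured so far in an assay on isolated protein for inhibition of Amine oxidase [flavin-containing] B (Homo sapiens), read by fluorescence, with a stated time of 15 min; on this read-out higher numbers stand for weaker inhibition and lower numbers for stronger inhibition:
compound 1 `O=C1OCc2cc(OCc3ccc(C(F)(F)F)cc3)ccc21` gives 6.41 nM;
compound 2 `O=c1ccoc2cc(OCc3ccc(C(F)(F)F)cc3)ccc12` gives 27.8 nM;
compound 3 `O=C1OCc2cc(OCc3ccc(Cl)cc3)ccc21` gives 13.9 nM.

Among these three numbers compound 3 stands second highest: compound 2 lies within the scatter of it, while compound 1 sits lower, beyond the scatter. The next compound, compound 4 `O=C1OCc2cc(OCc3ccc(F)cc3)ccc21`, differs from compound 3 in one place: fluoro in place of chloro on an aromatic carbon. Within the data shown here, only one measured step touches this spot: a 2.2-fold higher number from compound 1 to compound 3 (0.34 log units; beyond the scatter), a modest rise. Nothing measured shows what fluoro does here, so the expectation rests on that single step alone. A small move toward a higher number, or none beyond the scatter, is expected in this assay. For compound 4 the estimate is 20 nM, with a range from 7 nM to 60 nM. This amounts to an expected step of a 1.4-fold higher number from compound 3 to compound 4 (0.16 log units; within the scatter).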

Compound 4, half-maximal inhibitory concentration: 8.35 nM
Beside the measured number, compound 4's estimate is 2.4-fold (0.38 log units) above it, and the stated range covers the measured number.
By their numbers in this assay, from the lowest: compounds 1, 4, 3 and 2 (each within the scatter of the next, the first and the last beyond it).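

Fluoro on this aromatic carbon cannot be told apart from chloro, with a 1.7-fold lower number from compound 3 to compound 4 (0.22 log units; within the scatter), nor from trifluoromethyl, with a 1.3-fold higher number from compound 1 to compound 4 (0.11 log units; within the scatter). Chloro and trifluoromethyl do separate, with a 2.2-fold higher number from compound 1 to compound 3 (0.34 log units; beyond the scatter), so fluoro lies within the scatter of both ends of that small gap. Nothing at hand explains these results. On these data alone, it remains open whether an amine or a carboxylic acid in this place would keep the number in the same range. Also open, as far as these compounds go, is how fluoro behaves on the core of compound 2.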